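From 1H-pyrrol-1-yl to 1H-imidazol-1-yl at the assay limit

The compounds below may be only part of what the source reports. "The series", "measured", "known", "first", "only" and "open" are said of these compounds alone.

- Compound 1 `Cn1cc(C2=C(c3nn(CCCn4cncn4)c4ncccc34)C(=O)N(c3ccccc3)C2=O)c2ccccc21` gives > 100000 nM (a limit)
- Compound 2 `Cn1cc(C2=C(c3nn(CCCn4cccc4)c4ncccc34)C(=O)NC2=O)c2ccccc21` gives > 100000 nM (a limit)
- Compound 3 `Cn1cc(C2=C(c3nn(CCCN4CCCCC4)c4ncccc34)C(=O)N(c3ccccn3)C2=O)c2ccccc21` gives > 100000 nM (a limit)
- Compound 4 `Cn1cc(C2=C(c3nn(CCCn4ccnc4)c4ncccc34)C(=O)NC2=O)c2ccccc21` is not yet measured

These results come from a functional assay on SMMC-7721 cells (Homo sapiens) for antiproliferative activity, read by MTT assay, with a stated time of 48 h (on this read-out lower numbers stand for stronger inhibition and higher numbers for weaker inhibition), and none of them is an exact number. The whole set sits together, as shown by the limit of > 100000 nM in this assay, at which 3 of the 3 values shown sit, in this small series. Compound 2 stands at that limit with > 100000 nM and no exact number is known for it.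

The change to compound 4 is 1H-imidazol-1-yl in place of 1H-pyrrol-1-yl on a saturated chain carbon, three bonds along the chain from an aromatic nitrogen and it places 1H-imidazol-1-yl in place of 1H-pyrrol-1-yl on a saturated chain carbon, three bonds along the chain from an aromatic nitrogen. Within the data shown here, no measured pair here shows a step of this kind. The step expected in this assay is none beyond the scatter, estimated as a number no higher from compound 2 to compound 4 (the limit leaves the size open) for this single change. This expectation rests on compound 2 with its limit of > 100000 nM as the only starting point. Compound 4 is expected to stay close to the limit, with an estimated value of 100000 nM and an expected range from 30000 nM to 200000 nM in this test.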

Compound 4, half-maximal inhibitory concentration: > 100000 nM
Compound 4: a limit, no number; the forecaster's own chance of this, stated with the estimate: 80%; the middle value lies on the limit itself.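

No step can be read from compound 2 to compound 4, because both sit at the same limit and neither has an exact number: the limit of > 100000 nM in this assay, at which 4 of the 4 values shown sit.

The compounds shown leave open whether 1H-imidazol-1-yl in place of 1H-pyrrol-1-yl changes anything in this assay.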